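The source may report more compounds than this note shows. Statements on the series, on what has been measured and on what is new or still open speak of the compounds shown alone.

For the measured compounds named here, compound 2 `COc1cccc(NC(=O)N[C@H](C)c2ccccc2)c1` gives 92% in an ADME assay on the whole organism with Oryza sativa as the target, tested at 1 uM (a lower number here means a stronger effect, a higher number a weaker effect of the compound at the concentration tested), the second highest of the three numbers measured so far. Its nearest neighbour is compound 3 `COc1cccc(NC(=O)N[C@@H](C)c2ccccc2)c1`, which gives 99% in this assay; the step of a number 7 percentage points higher from compound 2 to compound 3 (within the scatter) lies within the scatter, and the two compounds differ only in configuration as drawn (the fact that compounds 2 and 3 differ only in the configuration as drawn). Furthest from compound 2 is compound 1 `C[C@@H](NC(=O)Nc1cccc(C(F)(F)F)c1)c1ccccc1`, which gives 72% in this assay; the step of a number 20 percentage points higher from compound 1 to compound 2 (beyond the scatter) is beyond the scatter and is the only modest step in the set.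

Compound 4 `C[C@@H](NC(=O)Nc1cccc(I)c1)c1ccccc1` has not yet been measured. It differs from compound 2 by the change (iodo in place of methoxy on an aromatic carbon).

Going by the values given here, of the measured steps, only the one from compound 1 to compound 2 bears on this change, since it also alters the group on the aromatic carbon of that ring, and it moved the number by a number 20 percentage points higher from compound 1 to compound 2 (beyond the scatter). The step between compound 2 and compound 3 concerns configuration alone and does not speak to a change of substituent. Because the step of a number 20 percentage points higher from compound 1 to compound 2 (beyond the scatter) shows that exchanging the group at this place can shift the read-out beyond the scatter, a shift of similar size in the lower direction is expected for compound 4, although the direction cannot be read from a single step. Compound 4 is therefore estimated at 78%, in the range 55% to 95%, an expected step of a number 14 percentage points lower from compound 2 to compound 4 (beyond the scatter).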

Compound 4, a percentage reported as activity, at one concentration (the size of the read-out at that concentration, not a potency): 75%
Estimate against measurement, compound 4: 3 percentage points above, and the stated range covers the measured number.
By their numbers in this assay, from the lowest: compounds 1 and 4 (each within the scatter of the next); then compounds 2 and 3 (each within the scatter of the next).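

In this assay, iodo in place of methoxy on the aromatic carbon gives a number 17 percentage points lower from compound 2 to compound 4 (beyond the scatter), so a second group, not only trifluoromethyl, now stands apart from methoxy at this position, and in the same direction. Iodo in place of trifluoromethyl gives a number 3 percentage points higher from compound 1 to compound 4 (within the scatter), so these two groups cannot be told apart here, even though they are different groups, and the earlier single contrast between compound 1 and compound 2 becomes a division of the three substituents into methoxy on one side and iodo and trifluoromethyl on the other. Nothing at hand says why methoxy parts from the other two groups at this position.

For the compounds shown here, with only three groups at this place, it remains open where others would fall, such as an amine, a hydroxy group, a carboxylic acid or a longer chain like ethoxy, and so whether methoxy is an exception or one end of a wider spread. From the compounds shown here alone, it also remains open whether the reversed configuration, which could not be separated from compound 2 with methoxy on the ring, would behave the same way with iodo or trifluoromethyl.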